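A few compounds are considered here, and "the series" means these few. Any claim that something is new, unique, unknown or untested is made for them only; others in the source may bear on it.

Measured compounds:
compound 1 `CCCC(=O)N1CCC(NS(=O)(=O)c2ccc(NC(=O)C3CCCCC3)c3ccccc23)CC1` – 6.1 nM
compound 2 `CCCC(=O)N1CCC(NS(=O)(=O)c2ccc(NC(=O)c3ccoc3)c3ccccc23)CC1` – 1520 nM

Both numbers come from an in vitro functional assay on CHO/Galpha16 cells for antagonist activity at C-C chemokine receptor type 8 (Homo sapiens), read by FLIPR; on this read-out higher numbers stand for weaker inhibition and lower numbers for stronger inhibition. Going by the values given here, compound 2 stands at the higher of the two numbers; the single step that separates it from compound 1 is a 250-fold higher number from compound 1 to compound 2 (2.40 log units; beyond the scatter), and it goes with furan-3-yl in place of cyclohexyl on the carbonyl carbon of the amide on the shared core.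

Compound 3 `CCCC(=O)N1CCC(NS(=O)(=O)c2ccc(NC(=O)c3cc(C)nc(Cl)c3)c3ccccc23)CC1` is not yet measured. It differs from compound 2 in the same position: 2-chloro-6-methylpyridin-4-yl in place of furan-3-yl on a carbonyl carbon. Among the compounds with values here, the only step that bears on this change is the one from compound 1 to compound 2, which shows that what sits on this carbonyl carbon can move the number a long way. Within the data shown here, the new group is neither the cyclohexyl of compound 1 nor the furan-3-yl of compound 2, so no measured pair tells the direction directly. On balance compound 3 is expected to land between the two measured numbers, with the estimate for compound 3 at 150 nM (range 15 nM to 1500 nM), which would mean an expected step of a 10-fold lower number from compound 2 to compound 3 (1.01 log units; beyond the scatter) in this assay.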

Compound 3, half-maximal inhibitory concentration: 43.9 nM
Estimate against measurement, compound 3: 3.4-fold (0.53 log units) above, and the stated range covers the measured number.
By their numbers in this assay, from the lowest: compound 1; then compound 3; then compound 2.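

In this assay, putting 2-chloro-6-methylpyridin-4-yl in place of furan-3-yl on the carbonyl carbon gives a 35-fold lower number from compound 2 to compound 3 (1.54 log units; beyond the scatter) and so shows that two aromatic rings with one hetero atom each are far from interchangeable at this place. The large rise seen with furan-3-yl is therefore not shared in full by every aromatic group, and much of it disappears with this pyridine. The recovery is incomplete, however: 2-chloro-6-methylpyridin-4-yl in place of cyclohexyl still gives a 7.2-fold higher number from compound 1 to compound 3 (0.86 log units; beyond the scatter) and leaves cyclohexyl with the lowest number of the three groups on this amide.

The compounds shown do not separate the contributions of the chlorine, the methyl and the six-membered ring, so a plain pyridin-4-yl, a phenyl, or a pyridine carrying only the chlorine or only the methyl would be needed to divide the step, and a cyclopentyl or a piperidine would test how far the cyclohexyl result extends. No measurement offered here explains why these groups differ as they do.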